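Opening a ring into a chain on the amine tail

The compounds below may be only part of what the source reports. "The series", "measured", "known", "first", "only" and "open" are said of these compounds alone.

Three compounds share one core and differ only in the amine that ends a side chain. In a physicochemical assay for lipophilicity, using the shake flask method, measured as octanol-water partition, at pH 7.4 (a higher number here means a more lipophilic compound, a lower number a more polar compound), compound 1 `COc1cc(/C=C/C(=O)Nc2ccccc2)ccc1OCCCN1CCCC1` gives 1.57, compound 2 `COc1cc(/C=C/C(=O)Nc2ccccc2)ccc1OCCCCN(C)C` gives 1.57 and compound 3 `COc1cc(/C=C/C(=O)Nc2ccccc2)ccc1OCCCCN1CCCC1` gives 1.6, the highest of the three, though a number 0.03 log units higher from compound 1 to compound 3 (within the scatter) and a number 0.03 log units higher from compound 2 to compound 3 (within the scatter) both stay inside the scatter, as does no change at the digits printed from compound 1 to compound 2 (within the scatter). Compound 4 `COc1cc(/C=C/C(=O)Nc2ccccc2)ccc1OCCCCCCN(C)C` differs from compound 3 by 2-(dimethylamino)ethyl in place of pyrrolidin-1-yl on a saturated chain carbon, four bonds along the chain from an oxygen on an aromatic ring. The change from compound 2 to compound 3 swapped the same two amine types and left this assay unmoved, so for compound 4 no step beyond the scatter is expected, a number 0.10 log units higher from compound 3 to compound 4 (within the scatter). Compound 4 is estimated at 1.7, within 1.3 to 2.1.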

Compound 4, partition coefficient: 1.69
Estimate against measurement, compound 4: 0.01 log units above, and the stated range covers the measured number.
By their numbers in this assay, from the lowest: compounds 1, 2, 3 and 4 (each within the scatter of the next).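

In this assay, opening the pyrrolidin-1-yl ring into the ring-free 2-(dimethylamino)ethyl at this position, with the heavy-atom count unchanged, stays within the scatter (a number 0.09 log units higher from compound 3 to compound 4 (within the scatter)). The comparisons with the shorter tails also stay within it (a number 0.12 log units higher from compound 2 to compound 4 (within the scatter); a number 0.12 log units higher from compound 1 to compound 4 (within the scatter)), so neither ring opening nor this added chain length separates these compounds. No measured evidence here explains this result. Still open, as far as these compounds go, is whether a morpholine ring, or a carboxylic acid in place of the amine, would also stay within the scatter.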